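The source may report more compounds than this note shows. Statements on the series, on what has been measured and on what is new or still open speak of the compounds shown alone.

Compound 1, `CC(=O)Nc1ccc(Nc2nccc(-c3ccccn3)n2)cc1`, sets the reference for this series. In a functional assay for inhibition, with Homo sapiens as the target (on this read-out lower numbers stand for stronger inhibition and higher numbers for weaker inhibition), compound 1 gives 1500 nM. Compound 2, `CC1CCN(c2ccc(Nc3nccc(-c4ccccn4)n3)cc2)CC1`, differs from compound 1 by 4-methylpiperidin-1-yl in place of acetamido on an aromatic carbon, and in this assay compound 2 gives 1900 nM; the resulting step is a 1.3-fold higher number from compound 1 to compound 2 (0.10 log units; within the scatter). Compound 3, `CC(=O)Nc1ccc(Nc2nccc(-c3ccncc3)n2)cc1`, carries a different core: its difference from compound 1 is pyridin-4-yl in place of pyridin-2-yl on an aromatic carbon. In this assay compound 3 gives 5300 nM, a step of a 3.5-fold higher number from compound 1 to compound 3 (0.55 log units; beyond the scatter), which leaves compound 3 with the highest number of the three.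

Compound 4, `CC1CCN(c2ccc(Nc3nccc(-c4ccncc4)n3)cc2)CC1`, is not yet measured. It differs from compound 3 by 4-methylpiperidin-1-yl in place of acetamido on an aromatic carbon, the same change that led from compound 1 to compound 2, at the same place. Because the step of a 1.3-fold higher number from compound 1 to compound 2 (0.10 log units; within the scatter) was within the scatter, compound 4 is expected to sit near compound 3, with an estimated step of a 1.2-fold higher number from compound 3 to compound 4 (0.09 log units; within the scatter) in this assay. Compound 4 is therefore expected at about 6500 nM, estimated to fall between 3000 nM and 14000 nM.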

Compound 4, half-maximal inhibitory concentration: 600 nM
Estimate against measurement, compound 4: 11-fold (1.03 log units) above; measured number outside the range, below it.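

On the core of compound 3, 4-methylpiperidin-1-yl in place of acetamido gives an 8.8-fold lower number from compound 3 to compound 4 (0.95 log units; beyond the scatter) in this assay, and this change does not carry over unaltered from the core of compound 1: the same change on two cores in this assay, a 1.3-fold higher number (0.10 log units; within the scatter) from compound 1 to compound 2 and an 8.8-fold lower number (0.95 log units; beyond the scatter) from compound 3 to compound 4, 11-fold (1.05 log units) apart, beyond the scatter of two such steps. Read the other way, pyridin-4-yl in place of pyridin-2-yl gives a 3.2-fold lower number from compound 2 to compound 4 (0.50 log units; beyond the scatter) where 4-methylpiperidin-1-yl is present, so in these four compounds the outcome of each change depends on the other: the same change on two cores in this assay, a 3.5-fold higher number (0.55 log units; beyond the scatter) from compound 1 to compound 3 and a 3.2-fold lower number (0.50 log units; beyond the scatter) from compound 2 to compound 4, 11-fold (1.05 log units) apart, beyond the scatter of two such steps. This shows that the two changes do not add up independently within this set, but it rests on a single square of four compounds and does not show why they interact or whether the same holds for other groups or cores.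

The compounds shown leave open whether another group on that aromatic carbon, such as a piperidine without the methyl, an open-chain amine or a longer chain, would behave like 4-methylpiperidin-1-yl. They also leave open whether the dependence seen here would appear with any other group in place of the two pyridinyl groups.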